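Dithiocarbamate ketones: benzyl ether to free phenol

This account rests on a few compounds, and the source may have more. Where it says the series, first, only, none or still open, it means among the compounds named here.

Measured so far:
- compound 1, `CC(=O)C(CSC(=S)N(C)C)CSC(=S)N(C)C` — 890 nM
- compound 2, `CN(C)C(=S)SCC(CSC(=S)N(C)C)C(=O)c1ccc(OCc2ccccc2)cc1` — 9770 nM

In a functional assay on NCI-H460 cells (Homo sapiens) for inhibition, read by MTT assay, with a stated time of 72 h (a lower number here means a stronger inhibitor, a higher number a weaker inhibitor), compound 2 gives the highest of the two numbers; the nearest, compound 1, sits at a lower number, a gap beyond the scatter. Both share the bis(dithiocarbamate) core; compound 1 carries an acetyl, compound 2 a benzyloxyphenyl ketone.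

Compound 3, `CN(C)C(=S)SCC(CSC(=S)N(C)C)C(=O)c1ccc(O)cc1`, keeps the aryl ketone of compound 2 and differs only by hydrogen in place of benzyl on an oxygen on an aromatic ring: the change, cut one bond further out, reads benzyloxy to hydroxy. Among the measured compounds shown here, no measured pair shows this change, so the size of its step in this assay is unknown. On the two numbers available, the smaller ketone of compound 1 sits at 890 nM, so a move toward the lower end is the more likely expectation, though the step could also be within the scatter.

Compound 3 is therefore estimated at 4000 nM, range 1000 nM to 15000 nM, an expected step of a 2.4-fold lower number from compound 2 to compound 3 (0.39 log units; beyond the scatter).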

Compound 3, half-maximal inhibitory concentration: 30000 nM
For compound 3 the middle estimate is 7.5-fold (0.88 log units) below the measured one, and the stated range ends below it.
By their numbers in this assay, from the lowest: compound 1; then compound 2; then compound 3.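

In this assay, hydrogen in place of benzyl on an oxygen on an aromatic ring gives a 3.1-fold higher number from compound 2 to compound 3 (0.49 log units; beyond the scatter), so removing the benzyl does not bring the number down toward that of the acetyl ketone. The aromatic ring and its benzyl group are therefore not what separates the aryl ketone from compound 1: 4-hydroxyphenyl in place of methyl on the carbonyl carbon gives a 34-fold higher number from compound 1 to compound 3 (1.53 log units; beyond the scatter). Nothing available explains either step.

On these data alone, whether a methoxy group, an amine or a carboxylic acid on this oxygen-bearing position of the ring would fall nearer hydroxy or benzyloxy remains open, as does the value of an unsubstituted phenyl ketone. A single pair at this oxygen gives one step, not a trend across substituents.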